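The source may report more compounds than this note shows. Statements on the series, on what has been measured and on what is new or still open speak of the compounds shown alone.

Working notes on the series in a functional assay on L1210 cells (Mus musculus) for inhibition, read by cell counting, with a stated time of 2 days; on this read-out lower numbers stand for stronger inhibition and higher numbers for weaker inhibition.

Compound 1 `COc1ccc(-c2nn3cc(-c4cccc(N)c4)nc3s2)cc1OC` gives 16000 nM in this assay. Compound 2 `C=C(Br)C(=O)Nc1cccc(-c2cn3nc(-c4ccc(OC)c(OC)c4)sc3n2)c1` gives 42 nM, and compound 3 `CCc1ccc(-c2nn3cc(-c4cccc(N)c4)nc3s2)cc1` gives 6000 nM. Compound 2 therefore stands lowest of the three numbers: its nearest neighbour is compound 3, and the step of a 380-fold lower number from compound 1 to compound 2 (2.58 log units; beyond the scatter) shows the acylation on the aromatic nitrogen as the large move in the set.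

Compound 4 `C=C(Br)C(=O)Nc1cccc(-c2cn3nc(-c4ccc(OC)cc4)sc3n2)c1` has not yet been measured. It differs from compound 2 by hydrogen in place of methoxy on an aromatic carbon. Among the compounds with values here, none of the measured steps covers this change: the one measured step concerns the nitrogen acyl group, not the methoxy pattern, and compounds 1 and 3, which do differ in the methoxy-bearing ring, also differ elsewhere and give only what their two values show. No direct evidence on the methoxy group is in hand, so the step of a 1.5-fold higher number from compound 2 to compound 4 (0.19 log units; within the scatter) is expected to stay within or near the scatter, leaning if anything toward a slightly higher number. Compound 4 is estimated at 65 nM, with a range from 20 nM to 220 nM.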

Compound 4, half-maximal inhibitory concentration: 940 nM
The estimate for compound 4 lay 14-fold (1.16 log units) below the measured number; the whole stated range lies below it.
By their numbers in this assay, from the lowest: compound 2; then compound 4; then compound 3; then compound 1.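

With the (1-bromoethenyl)carbonyl group held on the nitrogen, the change from 3,4-dimethoxyphenyl to 4-methoxyphenyl gives a 22-fold higher number from compound 2 to compound 4 (1.35 log units; beyond the scatter) in this assay. Within the data shown here, this is the first single-place reading on the methoxy pattern, and it shows that the methoxy group leaving here, ortho to a methoxy group, matters to the read-out; the step is printed as large, like the acylation step a 380-fold lower number from compound 1 to compound 2 (2.58 log units; beyond the scatter) on the nitrogen. The compounds shown offer no measurement that explains the size of this step.

It remains open whether the lower number of compound 2 needs a methoxy group specifically, since no hydroxyl, ethoxy or fluorine stands at this place among the compounds shown. Whether the step carries over to compounds with the free amine also remains unresolved.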